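The source may hold more compounds than are shown below. What is called first, only, known or untested is meant among the compounds shown, and "the series" means these compounds.

Measured in a functional assay on SU-DHL-6 cells (Homo sapiens) for antiproliferative activity, read by MTT assay; a higher number here means a weaker inhibitor, a lower number a stronger inhibitor:
- compound 1 `COc1ncc(-c2ccc3ncnc(N[C@H]4CCCN(C(=O)C(F)(F)F)C4)c3c2)cc1C#N`: 210 nM
- compound 2 `COc1ncc(-c2ccc3ncnc(N[C@H]4CCCN(C(=O)CCl)C4)c3c2)cc1C#N`: 380 nM
- compound 3 `CCOC(=O)CN1CCC[C@H](Nc2ncnc3ccc(-c4cnc(OC)c(C#N)c4)cc23)C1`: 500 nM

Compound 3 gives 500 nM. Its smaller gap is a 1.3-fold higher number from compound 2 to compound 3 (0.12 log units; within the scatter), and its larger gap is a 2.4-fold higher number from compound 1 to compound 3 (0.38 log units; beyond the scatter).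

Compound 4 `COc1ncc(-c2ccc3ncnc(N[C@H]4CCCN(C(=O)CN(C)C)C4)c3c2)cc1C#N` has ((dimethylamino)methyl)carbonyl in place of (ethoxycarbonyl)methyl on an amine nitrogen in a ring. Compound 4 therefore has a carbonyl-bearing group on that nitrogen, as compound 1 and compound 2 do. The closest evidence is the pair of steps already given, which run between those groups and (ethoxycarbonyl)methyl. Swapping the group on the carbonyl carbon gave only a 1.8-fold higher number from compound 1 to compound 2 (0.26 log units; within the scatter). For the measured compounds named here, no measured compound carries the dimethylamino group, so this evidence is indirect. In this assay, a small move to a lower number is expected, probably not beyond the scatter. The expected step is a 1.4-fold lower number from compound 3 to compound 4 (0.15 log units; within the scatter). For compound 4 the estimated value is 350 nM, with an expected range of 130 nM to 900 nM.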

Compound 4, half-maximal inhibitory concentration: 160 nM
Beside the measured number, compound 4's estimate is 2.2-fold (0.34 log units) above it, within the range that was stated.
By their numbers in this assay, from the lowest: compounds 4, 1, 2 and 3 (each within the scatter of the next, the first and the last beyond it).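

In this assay, ((dimethylamino)methyl)carbonyl on the amine nitrogen in the ring gives a 3.1-fold lower number from compound 3 to compound 4 (0.49 log units; beyond the scatter) and also a 2.4-fold lower number from compound 2 to compound 4 (0.38 log units; beyond the scatter) in the same series. The second of these steps shows that a change on the saturated chain carbon bound to the carbonyl carbon can move the number beyond the scatter, which the swap of trifluoromethyl for chloromethyl did not do. The remaining step is a 1.3-fold lower number from compound 1 to compound 4 (0.12 log units; within the scatter) and leaves (dimethylamino)methyl and trifluoromethyl on the carbonyl carbon unseparated in this assay, and no measurement here accounts for any of these steps.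

Still open, from the compounds shown here alone, is whether the dimethylamino group itself matters, or whether another amine, such as a primary amine, would give a similar number. A longer chain between that amine and the carbonyl, or a carboxylic acid in its place, is also untested by the compounds shown.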